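Swapping bromo for methoxy on a hydroxamic acid HDAC inhibitor

The compounds below may be only part of what the source reports. "The series", "measured", "known", "first", "only" and "open" are said of these compounds alone.

Measured so far:
- compound 1, `Cn1cc(/C=C/C(=O)c2ccc(F)cc2)cc1/C=C/C(=O)NO`: 24900 nM
- compound 2, `Cn1cc(/C=C/C(=O)c2cccc(Br)c2)cc1/C=C/C(=O)NO`: 480 nM

Both compounds were tested in an assay on isolated protein for inhibition of histone deacetylase HD1B (Zea mays); a lower number here means a stronger inhibitor, a higher number a weaker inhibitor. Compound 2 holds the lowest of the two numbers; its nearest neighbour, compound 1, sits far higher, as the step of a 52-fold lower number from compound 1 to compound 2 (1.71 log units; beyond the scatter) shows. For the measured compounds named here, that single step is the only comparison available, and it changes both the halogen and its position at once, so it gives no clean guide to the next change.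

Compound 3, `COc1cccc(C(=O)/C=C/c2cc(/C=C/C(=O)NO)n(C)c2)c1`, differs from compound 2 by methoxy in place of bromo on an aromatic carbon. Going by the values given here, no measured pair separates the effect of a methoxy from that of a bromo at the same place, so the expectation leans on compound 2 alone, whose value is 480 nM. A modest move toward a higher number is estimated for compound 3, as the step of a 3.1-fold higher number from compound 2 to compound 3 (0.49 log units; beyond the scatter) expresses. The expected value for compound 3 is 1500 nM, with a range from 300 nM to 8000 nM.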

Compound 3, half-maximal inhibitory concentration: 600 nM
Beside the measured number, compound 3's estimate is 2.5-fold (0.40 log units) above it; the range from low to high includes it.
By their numbers in this assay, from the lowest: compounds 2 and 3 (each within the scatter of the next); then compound 1.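

In this assay, the change at this aromatic carbon reads a 1.3-fold higher number from compound 2 to compound 3 (0.10 log units; within the scatter), so bromo and methoxy cannot be told apart here, although methoxy carries a hydrogen-bond acceptor and bromo does not. The second new step, a 42-fold lower number from compound 1 to compound 3 (1.62 log units; beyond the scatter), shows that a large difference from the 4-fluorophenyl compound is not unique to the 3-bromophenyl group, since the 3-methoxyphenyl group gives one too. Nothing measured here explains why these two groups give values within the scatter of each other.

Going by these compounds, compound 1 differs from compound 2 and compound 3 in both the group and its place on the ring, so which of these matters remains open. Also open, on these data alone, is how a different kind of group at this carbon, such as an amine or a carboxylic acid, would compare.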